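Bromo in Place of Methyl on Compound 1

The source may hold more compounds than are shown below. What is called first, only, known or untested is meant among the compounds shown, and "the series" means these compounds.

Compound 1 `Cc1ccc(/C=C/c2ccccc2O)cc1` and compound 2 `COc1cccc(/C=C\c2cc(OC)c(OC)c(OC)c2)c1O` were both tested in a functional assay on MDA-MB-468 cells (Homo sapiens) for antiproliferative activity, read by MTT assay; on this read-out lower numbers stand for stronger inhibition and higher numbers for weaker inhibition. Compound 1 gives 21900 nM in this assay, the higher of the two numbers. Compound 2 gives 2600 nM in this assay, a lower number, and the gap between the two lies beyond the usual scatter. Compound 2 differs from compound 1 in several places at once, so no single change can be tied to that gap.

Compound 3 `Oc1ccccc1/C=C/c1ccc(Br)cc1` has not yet been measured. It differs from compound 1 in one place only: bromo in place of methyl on an aromatic carbon. For the measured compounds named here, nothing among the measured pairs shows the effect of such a swap, so the expectation rests on compound 1 alone. A step of modest size is expected, a 1.5-fold lower number from compound 1 to compound 3 (0.16 log units; within the scatter), leaning toward a slightly lower number but possibly staying within the scatter. Compound 3 is therefore estimated at 15000 nM in this assay, within a range from 5000 nM to 45000 nM.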

Compound 3, half-maximal inhibitory concentration: 7400 nM
Beside the measured number, compound 3's estimate is 2.0-fold (0.31 log units) above it; measured number inside the range.
By their numbers in this assay, from the lowest: compound 2; then compound 3; then compound 1.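

In this assay, this position on the six-membered aromatic ring of carbon only, para to a group of 9 heavy atoms, proves responsive to substitution: bromo in place of methyl gives a 3.0-fold lower number from compound 1 to compound 3 (0.47 log units; beyond the scatter), a modest step but one that can be read as a real difference, which the earlier pair, differing in several places at once, could not provide. Methyl and bromo match in their counts of heavy atoms, rings, hydrogen-bond donors and acceptors and in net charge, so the number moves with no difference in any of those counts. There is no measurement at hand that ties the step to any particular property of the two groups.

From the compounds shown here alone, what remains open is whether the trend continues with other groups at this position, such as chloro, methoxy, an amine or a carboxylic acid, and whether any of them would move the number further than bromo does. Going by these compounds, it is also open whether the same swap of methyl for bromo would give a step of similar size on a different core.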